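Adding a chloro group to a phenylpiperazine quinoline

This account rests on a few compounds, and the source may have more. Where it says the series, first, only, none or still open, it means among the compounds named here.

Three compounds share one core and differ only in the group on the ring nitrogen. Compound 1 `NCCNc1cc(N2CCN(c3ccc(Cl)cc3)CC2)nc2ccccc12` carries a 4-chlorophenyl, and in an ADME assay on HEp-2 cells (Homo sapiens) for cytotoxicity, read by CCK-8 assay, with a stated time of 6 days (a lower number here means that less compound is tolerated, a higher number that more compound is tolerated), compound 1 gives 6600 nM. Compound 2 `NCCNc1cc(N2CCN(S(=O)(=O)c3ccccc3)CC2)nc2ccccc12` carries a phenylsulfonyl, and in this assay compound 2 gives 20500 nM. Compound 3 `NCCNc1cc(N2CCN(c3ccccc3)CC2)nc2ccccc12` carries a plain phenyl, and in this assay compound 3 gives 20800 nM, the highest of the three numbers, though its gap to compound 2 is within the scatter, so the two cannot be ordered; only compound 1 sits clearly lower, as shown by a 3.2-fold higher number from compound 1 to compound 3 (0.50 log units; beyond the scatter) and a 1.0-fold higher number from compound 2 to compound 3 (0.01 log units; within the scatter).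

Compound 4 `NCCNc1cc(N2CCN(c3cccc(Cl)c3)CC2)nc2ccccc12` is not yet measured. Its difference from compound 3 is chloro in place of hydrogen on an aromatic carbon, so the phenyl becomes a 3-chlorophenyl. Within the data shown here, the one measured step that bears on this is the reverse move, removing a chloro from the 4-chlorophenyl of compound 1, which gave a 3.2-fold higher number from compound 1 to compound 3 (0.50 log units; beyond the scatter), a modest rise. Putting a chloro back, even at a different position of the same ring, is therefore expected to lower the number by a similar modest amount, a 2.3-fold lower number from compound 3 to compound 4 (0.36 log units; beyond the scatter). Compound 4 is estimated at 9000 nM, with a range from 4000 nM to 21000 nM.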

Compound 4, half-maximal cytotoxic concentration: 6400 nM
Compound 4: middle estimate off by 1.4-fold (0.15 log units), on the high side; the range from low to high includes it.
By their numbers in this assay, from the lowest: compounds 4 and 1 (each within the scatter of the next); then compounds 2 and 3 (each within the scatter of the next).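

In this assay, chloro in place of hydrogen on an aromatic carbon of the phenyl gives a 3.3-fold lower number from compound 3 to compound 4 (0.51 log units; beyond the scatter), the first direct measure of adding this atom to the plain ring, and the 3-chlorophenyl likewise separates from the phenylsulfonyl, with a 3.2-fold lower number from compound 2 to compound 4 (0.51 log units; beyond the scatter). The comparison between the two chlorinated rings gives a 1.0-fold lower number from compound 1 to compound 4 (0.01 log units; within the scatter), so the 3-chlorophenyl and the 4-chlorophenyl cannot be told apart here, and the lower number seen earlier is not confined to the 4-chlorophenyl. Nothing available explains why chloro on either ring goes with less compound being tolerated.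

Going by these compounds, it remains open whether this drop is particular to chloro or would also follow from another group on the same ring, such as fluoro, methyl or methoxy. On these data alone, it is also open whether a second chloro on the phenyl, or an amine or a carboxylic acid in place of chloro, would move the number further down, leave it unchanged or bring it back up.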